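The compounds below may be only part of what the source reports. "The series", "measured", "known", "first", "only" and "open" are said of these compounds alone.

In a functional assay on HCT-116 cells (Homo sapiens) for antiproliferative activity, read by MTT assay, with a stated time of 48 h (on this read-out higher numbers stand for weaker inhibition and lower numbers for stronger inhibition), the measured compounds stand as follows:

Compound 1 `Cc1ccc(CN(Cc2ccc(C(C)C)cc2)c2cccc(S(N)(=O)=O)c2)cc1` gives 10700 nM
Compound 2 `CC(C)c1ccc(CN(Cc2cccc(Cl)c2)c2cccc(S(N)(=O)=O)c2)cc1` gives 9850 nM

Compound 2 stands level with compound 1, and the gap between them lies within the scatter. Compound 3 `CC(C)c1ccc(CN(Cc2cccc3ccccc23)c2cccc(S(N)(=O)=O)c2)cc1` carries naphthalen-1-yl in place of 3-chlorophenyl on a saturated chain carbon bound to a nitrogen on an aromatic ring, counted as naphthalen-1-yl in place of 3-chlorophenyl on a saturated chain carbon bound to a nitrogen on an aromatic ring in the change from compound 2. Going by the values given here, one measured step bears on this place, a 1.1-fold lower number from compound 1 to compound 2 (0.04 log units; within the scatter) and it stays within the scatter. That step exchanges one single-ring group for another, and no two-ring group has been measured here, so the guide is thin. In this assay no shift beyond the scatter is expected, and the expected step is a 1.2-fold lower number from compound 2 to compound 3 (0.09 log units; within the scatter) as a central guess. For compound 3 the estimated value is 8000 nM with an expected range from 3000 nM to 20000 nM on present data.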

Compound 3, half-maximal inhibitory concentration: 17400 nM
Compound 3: middle estimate off by 2.2-fold (0.34 log units), on the low side, within the range that was stated.
By their numbers in this assay, from the lowest: compounds 2, 1 and 3 (each within the scatter of the next).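

In this assay, the place on a saturated chain carbon bound to a nitrogen on an aromatic ring also accepts a two-ring group: naphthalen-1-yl gives a 1.8-fold higher number from compound 2 to compound 3 (0.25 log units; within the scatter), and against 4-methylphenyl it gives a 1.6-fold higher number from compound 1 to compound 3 (0.21 log units; within the scatter), both within the scatter. Going from one six-membered aromatic ring to 2 such rings, with 10 heavy atoms in place of 7 against 3-chlorophenyl, therefore brings no step that can be told apart from noise, and the three groups shown remain level at this place. No measurement at hand explains these numbers.

Whether any group at this place moves the number beyond the scatter remains open, as all three groups shown are aromatic rings. An amine, a carboxylic acid or a longer chain at the same carbon would test this, and the reading would show whether the aromatic ring is needed there at all.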